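The source may hold more compounds than are shown below. What is called first, only, known or untested is meant among the compounds shown, and "the series" means these compounds.

Two compounds sharing one core and differing only in a bromine-ending chain have been tested in a functional assay on ECa-109 cells for inhibition, with ECa-109 cell line (Homo sapiens) as the target, read by MTT assay, with a stated time of 48 h; a higher number here means a weaker inhibitor, a lower number a stronger inhibitor. Compound 1 `COc1ccc(-c2coc3cc(OCCCBr)ccc3c2=O)cc1` gives 39700 nM, and compound 2 `COc1ccc(-c2coc3cc(OCCCCCBr)ccc3c2=O)cc1` gives 59100 nM. These two values lie within the scatter of each other, so compound 2 cannot be ranked apart from compound 1 on these numbers.

Compound 3 `COc1ccc(-c2coc3cc(OCCCCBr)ccc3c2=O)cc1` is the next to consider. Going from compound 2 to compound 3, the structural change is bromo in place of bromomethyl on a saturated chain carbon, four bonds along the chain from an oxygen on an aromatic ring. The chain of compound 3 is thus shorter than that of compound 2 and longer than that of compound 1.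

Among the measured compounds shown here, only one measured step bears on this change, and it alters the same chain: a 1.5-fold higher number from compound 1 to compound 2 (0.17 log units; within the scatter). For the measured compounds named here, with so small a step as the only guide, no change beyond the scatter is expected in this assay. The expected step is a 1.2-fold lower number from compound 2 to compound 3 (0.09 log units; within the scatter). For compound 3 the estimated value is 48000 nM, with an expected range of 26000 nM to 85000 nM.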

Compound 3, half-maximal inhibitory concentration: 66300 nM
Compound 3: the middle estimate sits 1.4-fold (0.14 log units) below what was measured; measured number inside the range.
By their numbers in this assay, from the lowest: compounds 1, 2 and 3 (each within the scatter of the next).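

In this assay, the third chain length adds a step that could have separated the series, and it does not: the change gives a 1.1-fold higher number from compound 2 to compound 3 (0.05 log units; within the scatter), and the comparison with the shortest chain gives a 1.7-fold higher number from compound 1 to compound 3 (0.22 log units; within the scatter). Together with the first pair, this means that all three chain lengths now sit within the scatter of their neighbours, so adding or removing a single chain carbon at this position shows no readable effect on the number, and the intermediate chain stands out from neither of the other two. No independent measurement is available to explain this result.

The compounds shown all keep the bromine at the chain end, so they leave open whether an amine, a carboxylic acid or a plain hydrogen in that place would move the number beyond the scatter. They also leave open whether a much longer chain, or a much shorter one such as a bare methoxy group on the same oxygen, would separate from these three compounds in this cell assay.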